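The compounds below may be only part of what the source reports. "The series", "measured", "known", "first", "only" and "open" are said of these compounds alone.

Series notes. Compound 1 `CCCCC1=NC2(CCCC2)C(=O)N1C(=O)COc1ccc(/C=C2/SC(=O)NC2=O)cc1`, compound 2 `O=C(COc1ccc(/C=C2\SC(=O)NC2=O)cc1)Nc1cccc(C(F)(F)F)c1` and compound 3 `O=C(COc1ccc(/C=C2\SC(=O)NC2=O)cc1)Nc1ncc([N+](=O)[O-])s1` share one core and have been tested in a functional assay on PC-3 cells (Homo sapiens) for cytotoxicity, read by sulforhodamine B assay, with a stated time of 48 h; a higher number here means a weaker inhibitor of growth, a lower number a stronger inhibitor of growth. Compound 1 is reported there only as a limit, < 100000 nM. Compound 2 likewise stands only at a limit, < 100000 nM. Compound 3 too is recorded as a limit and nothing more, < 100000 nM, so its standing is known only as far as the limit of < 100000 nM in this assay, at which 3 of the 3 values shown sit. Compound 4 `Cc1cc(NC(=O)COc2ccc(/C=C3\SC(=O)NC3=O)cc2)no1` is not yet measured; it differs from compound 3 by 5-methyl-1,2-oxazol-3-yl in place of 5-nitro-1,3-thiazol-2-yl on an amide-type nitrogen. Within the data shown here, with every value shown a limit, no step between measured compounds can be read, and the expected step that the limit leaves unreadable from compound 3 to compound 4 is none beyond the scatter. Compound 4 is estimated at 50000 nM, between 10000 nM and 100000 nM.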

Compound 4, concentration for total growth inhibition: < 100000 nM
Compound 4: no number, only a limit; the forecaster's own chance of this, stated with the estimate: 75%; the middle value lies beyond the limit too.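

No step from compound 3 to compound 4 can be read, as both values are limits and not numbers: the limit of < 100000 nM in this assay, at which 4 of the 4 values shown sit.

The compounds shown leave open how 5-methyl-1,2-oxazol-3-yl and 5-nitro-1,3-thiazol-2-yl compare on the amide-type nitrogen, as no compound here has a value that is a number.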